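The source may report more compounds than this note shows. Statements on the series, on what has been measured and on what is new or still open speak of the compounds shown alone.

Compound 1 `Cc1ccc(C(=O)Nc2nc(Cl)c3cn(C)nc3n2)cc1` is one of two measured members of this small series. In a functional assay on CHO cells for antagonist activity at adenosine receptor A2b (Homo sapiens), read by 33P incorporation, with a stated time of 20 min, in the presence of a further agent that is not named here (a higher number here means a weaker inhibitor, a lower number a stronger inhibitor), compound 1 gives only a limit, > 20000 nM. Its companion, compound 2 `Cn1cc2c(Cl)nc(NC(=O)c3ccc(F)cc3)nc2n1`, carries fluoro in place of methyl on an aromatic carbon. In this assay compound 2 likewise gives only a limit, > 20000 nM. The step that the two limits leave unreadable from compound 1 to compound 2 therefore cannot be read, because both values sit at the limit of > 20000 nM in this assay, at which 2 of the 2 values shown sit.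

Compound 3 `Cc1ccc(C(=O)Nc2nc(Cl)c3cn(C(C)C)nc3n2)cc1` differs from compound 1 as follows: isopropyl in place of methyl on an aromatic nitrogen. Within the data shown here, no measured step touches this position, and the single measured step gives no readable size, so there is no footing to expect any change beyond the usual scatter. The step that the limit leaves unreadable from compound 1 to compound 3 is therefore expected to be small or absent. For compound 3 in this assay the estimate is 30000 nM, between 8000 nM and 120000 nM.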

Compound 3, inhibition constant: > 20000 nM
Compound 3 gave a limit, no number; the forecaster's own chance of this, stated with the estimate: 80%; the middle value does not contradict the limit.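

Among these compounds, compound 3, like compound 1, gives only a limit in this assay, so no step between compound 1 and compound 3 can be read: the limit of > 20000 nM in this assay, at which 3 of the 3 values shown sit. The compounds shown leave open how strongly any of them inhibits, and whether isopropyl in place of methyl on the aromatic nitrogen makes any difference.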